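The source may report more compounds than this note shows. Statements on the series, on what has been measured and on what is new or still open speak of the compounds shown alone.

Three compounds share one core and differ only in the aromatic ring attached to the carbon that carries a double bond to nitrogen. Compound 1 `CC1=CC[C@@H]([C@@](C)(O)CCCC(C)(C)NC(=S)N/N=C\c2ccccc2)CC1` carries a plain phenyl ring; in a functional assay on K562 cells (Homo sapiens) for cytotoxicity, read by sulforhodamine B assay (a lower number here means that less compound is tolerated, a higher number that more compound is tolerated), compound 1 gives > 100000 nM, which is a limit of the assay rather than a number. Compound 2 `CC1=CC[C@@H]([C@@](C)(O)CCCC(C)(C)NC(=S)N/N=C\c2ccc(N(C)C)cc2)CC1` carries a 4-(dimethylamino)phenyl ring, and in this assay compound 2 also gives > 100000 nM, again a limit and not a number. Compound 3 `CC1=CC[C@@H]([C@@](C)(O)CCCC(C)(C)NC(=S)N/N=C\c2cccc([N+](=O)[O-])c2)CC1` carries a 3-nitrophenyl ring and is the only one of the three with a measured number, giving 12600 nM in this assay. The step from the phenyl to the nitrophenyl ring is an at least 7.9-fold lower number from compound 1 to compound 3 (0.89 log units; beyond the scatter), and from the dimethylaminophenyl ring an at least 7.9-fold lower number from compound 2 to compound 3 (0.89 log units; beyond the scatter); both start from the limit of > 100000 nM in this assay, at which 2 of the 3 values shown sit.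

Compound 4 `CC1=CC[C@@H]([C@@](C)(O)CCCC(C)(C)NC(=S)N/N=C\c2ccccc2Cl)CC1` is the next compound, with the change (2-chlorophenyl in place of 3-nitrophenyl on a carbon with a double bond to nitrogen). Among the measured compounds shown here, no measured step covers a chlorine on this ring. What the measured steps show is that compound 1 without the nitro group sat at the limit and compound 3 with it gave a number, as an at least 7.9-fold lower number from compound 1 to compound 3 (0.89 log units; beyond the scatter) records. Since compound 4 drops the nitro group, the expected step is a 4.8-fold higher number from compound 3 to compound 4 (0.68 log units; beyond the scatter), and compound 4 is estimated to give 60000 nM in this assay, within 15000 nM to 200000 nM, quite possibly reported only as a limit.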

Compound 4, concentration lethal to 50% of the cells: 8500 nM
For compound 4 the middle estimate is 7.1-fold (0.85 log units) above the measured one; measured number outside the range, below it.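

Compound 4 shows that a nitro group is not required for a measured number in this assay: chloro in place of hydrogen gives an at least 11-fold lower number from compound 1 to compound 4 (1.07 log units; beyond the scatter). Replacing the 3-nitrophenyl ring with the 2-chlorophenyl ring gives a 1.5-fold lower number from compound 3 to compound 4 (0.17 log units; within the scatter), so this assay does not separate these two rings, although both the group and its place on the ring differ, while compound 2 shows that not every group on the ring gives a measured number. The 2-chlorophenyl ring also gives an at least 11-fold lower number from compound 2 to compound 4 (1.07 log units; beyond the scatter), and this step and the one from compound 1 are minimum sizes rather than true sizes, as each begins at a limit and not a number: the limit of > 100000 nM in this assay, at which 2 of the 4 values shown sit.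

The compounds shown leave open whether chlorine itself matters or whether its place on the ring matters, since chlorine appears at only one place and the nitro group at only one other. They also leave open whether a bromine, a methoxy group or a carboxylic acid on the ring would give a measured number in this assay, and whether any such ring would differ beyond the scatter from the 3-nitrophenyl and 2-chlorophenyl rings.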